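The source may hold more compounds than are shown below. What is called first, only, known or untested is meant among the compounds shown, and "the series" means these compounds.

Measured in a functional assay on SGC-7901 cells (Homo sapiens) for cytotoxicity, read by MTT assay, with a stated time of 48 h; on this read-out lower numbers stand for stronger inhibition and higher numbers for weaker inhibition:
Compound 1 `O=C(CSc1ccccc1)N1N=C(c2cc3ccccc3oc2=O)C[C@@H]1c1ccccc1`: 20300 nM
Compound 2 `CC1=NN(C(=O)CSc2ccccn2)[C@@H](c2cc(Br)cc(Br)c2O)C1`: 10300 nM

On these numbers, compound 2 cannot be told apart from compound 1, as their two values lie within the usual scatter of each other. Compound 3 `CC1=NN(C(=O)CSc2ccccc2)[C@@H](c2cc(Br)cc(Br)c2O)C1` carries phenyl in place of pyridin-2-yl on a sulfur. Among the compounds with values here, no measured pair shows this change, so no step beyond the scatter is expected in this assay, in either direction. The expected size of the change is a 1.1-fold lower number from compound 2 to compound 3 (0.06 log units; within the scatter). The estimated value for compound 3 is 9000 nM, with an expected range from 3200 nM to 25000 nM.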

Compound 3, half-maximal inhibitory concentration: 24100 nM
The estimate for compound 3 lay 2.7-fold (0.43 log units) below the measured number; the range from low to high includes it.
By their numbers in this assay, from the lowest: compounds 2, 1 and 3 (each within the scatter of the next, the first and the last beyond it).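

Putting phenyl in place of pyridin-2-yl on the sulfur gives a 2.3-fold higher number from compound 2 to compound 3 (0.37 log units; beyond the scatter) in this assay. Within the data shown here, this is the first measured step at this position, and it shows that the read-out responds to a swap of one ring nitrogen for carbon, though the step is modest and rests on one pair. Nothing measured here accounts for the step.

Open, as far as these compounds go, is how a pyrimidin-2-yl or a benzyl group on this sulfur would compare. Also open, from the compounds shown here alone, is whether the same swap gives a similar step on the core of compound 1.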